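A few compounds are considered here, and "the series" means these few. Any claim that something is new, unique, unknown or untested is made for them only; others in the source may bear on it.

Compound 1 `O=C(CSc1nc(Nc2ccccc2)c2ccccc2n1)Nc1ccccc1Br` and compound 2 `COc1cccc(NC(=O)CSc2nc(Nc3ccccc3)c3ccccc3n2)c1` share one core and differ only in the aryl group carried on the amide-type nitrogen. In a functional assay on MDA-MB-231 cells (Homo sapiens) for inhibition, read by MTT assay, with a stated time of 72 h (a lower number here means a stronger inhibitor, a higher number a weaker inhibitor), compound 1 gives 14100 nM, and in this assay compound 2 gives 21700 nM. Among the measured compounds shown here, the one measured step, a 1.5-fold higher number from compound 1 to compound 2 (0.19 log units; within the scatter), does not leave the scatter. On the numbers shown, compound 2 stands at the highest of the two, with compound 1 nearest at a gap that is within the scatter, so the two cannot be ranked.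

Compound 3 `O=C(CSc1nc(Nc2ccccc2)c2ccccc2n1)Nc1ccc([N+](=O)[O-])cc1` has not yet been measured. It differs from compound 2 by 4-nitrophenyl in place of 3-methoxyphenyl on an amide-type nitrogen. For the measured compounds named here, the only measured step that bears on it is the exchange of one aryl group for another at the same amide-type nitrogen, and that exchange stayed within the scatter. There is therefore no measured ground for expecting a move in either direction, and for compound 3 in this assay a step of a 1.1-fold lower number from compound 2 to compound 3 (0.04 log units; within the scatter) is expected, which is none beyond the scatter. Compound 3 is accordingly estimated at 20000 nM, with a range from 7000 nM to 60000 nM.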

Compound 3, half-maximal inhibitory concentration: 16800 nM
Compound 3: the middle estimate sits 1.2-fold (0.08 log units) above what was measured, within the range that was stated.
By their numbers in this assay, from the lowest: compounds 1, 3 and 2 (each within the scatter of the next).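

In this assay, the amide-type nitrogen now carries a third aryl group, and a 1.3-fold lower number from compound 2 to compound 3 (0.11 log units; within the scatter) and a 1.2-fold higher number from compound 1 to compound 3 (0.08 log units; within the scatter) both stay inside the scatter, so all the exchanges seen at this position have left the number unresolved. The change to 4-nitrophenyl is also a different kind of change from the earlier one, since it brings nitrogen and a double bond outside aromatic rings, yet these additions produce no step that can be told from repeat measurement among these three compounds. No independent measurement is available to bear on this result.

All three groups on this nitrogen are substituted phenyl rings that differ in both substituent and printed ring position, so the compounds shown cannot separate the effect of the substituent from that of its place on the ring, and they do not show whether this position can produce a step beyond the scatter at all. Still open, on these data alone, is what would happen with a group of another type on this nitrogen, such as a saturated amine, a carboxylic acid on the ring, or a longer chain set between the nitrogen and the ring.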